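The source may hold more compounds than are shown below. What is called first, only, known or untested is meant among the compounds shown, and "the series" means these compounds.

Among the measured compounds shown here, in a functional assay on MCF7 cells (Homo sapiens) for antiproliferative activity, read by MTT assay, with a stated time of 72 h (on this read-out lower numbers stand for stronger inhibition and higher numbers for weaker inhibition), compound 2, `O=S(=O)(Oc1ccccc1)C1CC2OC1C(c1ccc(/C=C/c3cc(O)cc(O)c3)cc1)=C2c1ccc(O)cc1`, gives 20100 nM, the only true number available so far. Compound 1, `COc1cc(/C=C/c2ccc(C3=C(c4ccc(O)cc4)C4CC(S(=O)(=O)Oc5ccc(Br)cc5)C3O4)cc2)cc(OC)c1`, gives > 100000 nM, which is a limit of the assay rather than a number. Compound 3, `O=S(=O)(Oc1ccc(Br)cc1)C1CC2OC1C(c1ccc(/C=C/c3cc(O)cc(O)c3)cc1)=C2c1ccc(O)cc1`, has not yet been measured. It differs from compound 2 by bromo in place of hydrogen on an aromatic carbon, para to a large group, so that phenoxy becomes 4-bromophenoxy. For the measured compounds named here, no measured step in this assay isolates this change. A single added atom on this outer ring is therefore expected to make little difference, probably none beyond the usual scatter, with any shift slightly towards stronger inhibition. The expected step of a 1.3-fold lower number from compound 2 to compound 3 (0.13 log units; within the scatter) is correspondingly small. For compound 3, the estimated value is 15000 nM, with an expected range of 6000 nM to 45000 nM.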

Compound 3, half-maximal inhibitory concentration: 16900 nM
The estimate for compound 3 lay 1.1-fold (0.05 log units) below the measured number, and the stated range covers the measured number.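

In this assay, bromo in place of hydrogen on the aromatic carbon para to a large group gives a 1.2-fold lower number from compound 2 to compound 3 (0.08 log units; within the scatter), so this position accepts a bromine with no change that can be told from the scatter, and phenoxy and 4-bromophenoxy cannot be separated here. With 4-bromophenoxy held in place, 3,5-dihydroxyphenyl in place of 3,5-dimethoxyphenyl gives an at least 5.9-fold lower number from compound 1 to compound 3 (0.77 log units; beyond the scatter), a step beyond the scatter, so in this set the read-out responds to that change and not to the bromo. Compound 1 carries a limit rather than a number, so the full size of that step cannot be read: the limit of > 100000 nM in this assay, at which 1 of the 3 values shown sits.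

The compounds shown leave open whether an amine or a carboxylic acid on this outer ring would shift the number beyond the scatter. They also leave open whether a single hydroxy group could stand in for the two in 3,5-dihydroxyphenyl.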